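Replacing a pyridinylmethyl urea end with cyclopentyl

This account rests on a few compounds, and the source may have more. Where it says the series, first, only, none or still open, it means among the compounds named here.

Three urea derivatives sharing one core have been tested in a functional assay on L1210 cells (Mus musculus), read by MTT assay, with a stated time of 72 h; a higher number here means a weaker inhibitor, a lower number a stronger inhibitor. Compound 1 `COc1cc(NC(C)CCCNC(=O)NC(c2ccccc2)c2ccccc2)c2ncccc2c1` reaches only the limit of the assay, > 500000 nM, and so gives no number. Among the compounds with values here, compound 2 `COc1cc(NC(C)CCCNC(=O)NCc2ccncc2)c2ncccc2c1` gives 3000 nM, the lowest of the two numbers known. Within the data shown here, its nearest neighbour is compound 3 `CCN(CC)C(=O)NCCCC(C)Nc1cc(OC)cc2cccnc12` with 207000 nM; that gap is the one measured step, a 69-fold higher number from compound 2 to compound 3 (1.84 log units; beyond the scatter), a change at the urea carbonyl.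

Compound 4 `COc1cc(NC(C)CCCNC(=O)NC2CCCC2)c2ncccc2c1` is not yet measured. It differs from compound 2 by cyclopentyl in place of (pyridin-4-yl)methyl on an amide-type nitrogen. As in the step from compound 2 to compound 3, the (pyridin-4-yl)methyl group leaves the urea end, although what enters this time is cyclopentyl rather than diethylamino. Among the measured compounds shown here, that single measured step, a 69-fold higher number from compound 2 to compound 3 (1.84 log units; beyond the scatter), is the only guide, and it points towards a clearly weaker inhibitor, with the exact size uncertain. Compound 4 is therefore estimated at 40000 nM, expected to lie between 6000 nM and 250000 nM. This expectation corresponds to a step of a 13-fold higher number from compound 2 to compound 4 (1.12 log units; beyond the scatter).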

Compound 4, half-maximal inhibitory concentration: 41000 nM
Compound 4: middle estimate off by 1.0-fold (0.01 log units), on the low side; the range from low to high includes it.
By their numbers in this assay, from the lowest: compound 2; then compound 4; then compound 3. At a limit, above all of these: compound 1.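

In this assay, a second replacement of the (pyridin-4-yl)methyl group also raises the number: a 14-fold higher number from compound 2 to compound 4 (1.14 log units; beyond the scatter). Both replacements at this urea end, the cyclopentyl group here and the diethylamino group earlier, therefore give a weaker inhibitor than the pyridine-bearing end. What enters matters as well, not only what leaves, since two ends without a pyridine ring still differ clearly: a 5.0-fold lower number from compound 3 to compound 4 (0.70 log units; beyond the scatter).

The compounds shown do not tell whether the advantage of the (pyridin-4-yl)methyl end rests on its ring nitrogen, which a benzyl group would test, or on its place in the ring, which a (pyridin-3-yl)methyl group would test. Compound 1 stands at a limit, so steps to it cannot be read: the limit of > 500000 nM in this assay, at which 1 of the 4 values shown sits.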